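Notes on the amide substituent of the shared core

The source may hold more compounds than are shown below. What is called first, only, known or untested is meant among the compounds shown, and "the series" means these compounds.

Of the compounds shown here, two of the shared core have been measured in a functional assay on MDA-MB-231 cells (Homo sapiens) for antiproliferative activity, read by MTT assay, with stated times of 72 h and 4 h; on this read-out higher numbers stand for weaker inhibition and lower numbers for stronger inhibition. Compound 1 `Cc1nc(C(=O)Nc2ccc(Cl)c(-c3nnc4c(Cl)cccn34)c2)cs1` returns no number in this assay but a limit, > 100000 nM. Compound 1 thus sits at the limit of > 100000 nM in this assay, at which 1 of the 2 values shown sits. For the measured compounds named here, compound 2 `O=C(Nc1ccc(Cl)c(-c2nnc3c(Cl)cccn23)c1)c1cccc(Cl)c1` gives 66100 nM in this assay, and that is the only number in the set so far. The step of an at least 1.5-fold lower number from compound 1 to compound 2 (0.17 log units; that floor lies within the scatter) is all the measured evidence there is on changing the group at the carbonyl carbon.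

Compound 3 `O=C(Nc1ccc(Cl)c(-c2nnc3c(Cl)cccn23)c1)c1c(F)cccc1Cl` is not yet measured. It differs from compound 2 by 2-chloro-6-fluorophenyl in place of 3-chlorophenyl on a carbonyl carbon. Going by the values given here, no measured step carries this same change; the single step available, an at least 1.5-fold lower number from compound 1 to compound 2 (0.17 log units; that floor lies within the scatter), concerns a different substituent and rests on a limit, so it offers no scale for the present change. The expectation is therefore a step of a 1.1-fold lower number from compound 2 to compound 3 (0.04 log units; within the scatter) that stays within the scatter of this assay, in no settled direction. Compound 3 is estimated at 60000 nM in this assay, with a range from 20000 nM to 150000 nM.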

Compound 3, half-maximal inhibitory concentration: > 100000 nM
Compound 3: only a limit was reported; the forecaster's own chance of this, stated with the estimate: 35%; middle value at least 1.6-fold (0.22 log units) from the limit.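

Moving from 3-chlorophenyl to 2-chloro-6-fluorophenyl on the carbonyl carbon gives, in this assay, an at least 1.5-fold higher number from compound 2 to compound 3 (0.17 log units; that floor lies within the scatter), and this floor does not establish a real loss. Compound 3 returns only a limit, > 100000 nM, so the second phenyl group at this position does not add a second number to the set. The step from compound 1 to compound 3 cannot be read, and 3-chlorophenyl remains the only group here with a number, while the thiazole and the 2-chloro-6-fluorophenyl group both leave the series at the limit: the limit of > 100000 nM in this assay, at which 2 of the 3 values shown sit.

The compounds shown leave open whether any group on this carbonyl carbon gives a step from compound 2 that lies beyond the scatter, and with no scale yet for this position, a plain phenyl, a 4-methoxyphenyl or a saturated ring such as piperidine could each supply the next reference point. They also do not separate the chlorine from the fluorine of the 2-chloro-6-fluorophenyl group, since both enter together in compound 3.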